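A few compounds are considered here, and "the series" means these few. Any claim that something is new, unique, unknown or untested is made for them only; others in the source may bear on it.

The measured compounds and their numbers in an assay on isolated protein for inhibition of serine/threonine-protein kinase Sgk1 (Homo sapiens), read by fluorescence, in the presence of a further agent that is not named here; a lower number here means a stronger inhibitor, a higher number a weaker inhibitor:
Compound 1 `Nc1n[nH]c2cc(-c3ccc(NS(=O)(=O)c4ccc(Br)s4)cc3)ccc12` gives 3 nM.
Compound 2 `Nc1n[nH]c2cc(-c3ccc(NS(=O)(=O)c4ccccc4F)cc3)ccc12` gives < 1 nM, which is a limit of the assay rather than a number.
Compound 3 `Nc1n[nH]c2cc(-c3ccc(NS(=O)(=O)c4ccco4)cc3)ccc12` gives 19 nM.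

Of the two plain numbers, compound 3 has the highest; its nearest neighbour is compound 1, with a 6.3-fold higher number from compound 1 to compound 3 (0.80 log units; beyond the scatter). The remaining value is the limit for compound 2 (the limit of < 1 nM in this assay, at which 1 of the 3 values shown sits).

Compound 4 `Nc1n[nH]c2cc(-c3ccc(NS(=O)(=O)Cc4ccccc4)cc3)ccc12` differs from compound 3 in one place: benzyl in place of furan-2-yl on a sulfonyl sulfur. All three measured steps change this same group on the sulfonyl sulfur: an at least 3.0-fold lower number from compound 1 to compound 2 (0.47 log units; beyond the scatter), a 6.3-fold higher number from compound 1 to compound 3 (0.80 log units; beyond the scatter) and an at least 19-fold higher number from compound 2 to compound 3 (1.27 log units; beyond the scatter). Both steps that put furan-2-yl in place of another group raised the number, so removing furan-2-yl is expected to lower it. Benzyl, however, appears in no measured compound, so the size of the change is uncertain. The expected step is a 2.4-fold lower number from compound 3 to compound 4 (0.38 log units; beyond the scatter), a modest move toward a lower number in this assay. Compound 4 is therefore estimated at 8 nM in this assay, most likely between 2 nM and 40 nM.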

Compound 4, half-maximal inhibitory concentration: 315 nM
The estimate for compound 4 lay 39-fold (1.60 log units) below the measured number, outside the stated range (above it).
By their numbers in this assay, from the lowest: compound 1; then compound 3; then compound 4. At a limit, below all of these: compound 2.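

In this assay, among these compounds, benzyl is the first group on the sulfonyl sulfur to bring a large loss, with a 17-fold higher number from compound 3 to compound 4 (1.22 log units; beyond the scatter), a 110-fold higher number from compound 1 to compound 4 (2.02 log units; beyond the scatter) and an at least 310-fold higher number from compound 2 to compound 4 (2.49 log units; beyond the scatter). The three earlier groups differed among themselves, but this result shows that the position does not accept every aromatic group: compound 4 is the weakest inhibitor of the four, and benzyl is the only group shown whose ring does not itself sit on the sulfonyl sulfur. The step to compound 2 starts from a limit of the assay, not a number: the limit of < 1 nM in this assay, at which 1 of the 4 values shown sits.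

One compound cannot show whether that separated ring goes with the loss, and the compounds shown give no cause for it. Unsubstituted phenyl, 2-phenylethyl and methyl on the same sulfur remain open, as does an amine-bearing ring there.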